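A few compounds are considered here, and "the series" means these few. Any claim that something is new, unique, unknown or untested is made for them only; others in the source may bear on it.

Three compounds sharing one core, differing in a single phenyl group, have been measured in a functional assay on MCF7 cells (Homo sapiens) for antiproliferative activity, read by MTT assay, with a stated time of 72 h (a lower number here means a stronger inhibitor, a higher number a weaker inhibitor), so far. Compound 1 (`COc1cc(-n2cnc3ccc(-c4cc(F)ccc4F)cc32)cc(OC)c1OC`) gives 6420 nM with its 2,5-difluorophenyl group, and compound 2 (`COc1cc(-n2cnc3ccc(-c4ccc(Cl)cc4)cc32)cc(OC)c1OC`) gives 1320 nM with its 4-chlorophenyl group. Compound 3 (`COc1ccc(-c2ccc3ncn(-c4cc(OC)c(OC)c(OC)c4)c3c2)cc1`) gives 210 nM with its 4-methoxyphenyl group, the lowest number of the three.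

Compound 4 (`COc1cc(-n2cnc3ccc(-c4ccc(F)cc4)cc32)cc(OC)c1OC`) has fluoro in place of methoxy on an aromatic carbon, para to a large group (fluoro in place of methoxy on an aromatic carbon), which turns the 4-methoxyphenyl of compound 3 into 4-fluorophenyl.

The closest guide is the modest step of a 6.3-fold lower number from compound 2 to compound 3 (0.80 log units; beyond the scatter) (methoxy in place of chloro on an aromatic carbon), and the new change leaves methoxy in the opposite direction. The large step of a 31-fold lower number from compound 1 to compound 3 (1.49 log units; beyond the scatter) points the same way, and the modest step of a 4.9-fold lower number from compound 1 to compound 2 (0.69 log units; beyond the scatter) shows that the two halogen-bearing groups differ from each other. For the measured compounds named here, no measured compound carries the 4-fluorophenyl group itself, so the size remains uncertain.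

A modest move towards a higher number, a weaker inhibitor, is therefore expected in this assay, with an estimated 5.2-fold higher number from compound 3 to compound 4 (0.72 log units; beyond the scatter) as the likely step. Compound 4 is estimated at 1100 nM with an expected range from 350 nM to 3500 nM in this test.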

Compound 4, half-maximal inhibitory concentration: 1770 nM
Beside the measured number, compound 4's estimate is 1.6-fold (0.21 log units) below it; low and high end bracket the measured number.
By their numbers in this assay, from the lowest: compound 3; then compounds 2 and 4 (each within the scatter of the next); then compound 1.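

In this assay, fluoro in place of methoxy para to a large group takes the number well up (an 8.4-fold higher number from compound 3 to compound 4 (0.93 log units; beyond the scatter)), so the methoxy of compound 3 now stands apart from a second halogen as well as from chloro. Fluoro and chloro at this place cannot be told apart (a 1.3-fold higher number from compound 2 to compound 4 (0.13 log units; within the scatter)), so among these two para halogens, the identity of the halogen makes no measurable difference, and methoxy is the only group of the three that shifts the number clearly. For the compounds shown here, the 4-fluorophenyl group also gives a lower number than the 2,5-difluorophenyl group (a 3.6-fold lower number from compound 1 to compound 4 (0.56 log units; beyond the scatter)), which shows that two fluorophenyl groups can differ clearly from each other, while compound 1 remains the only compound with a halogen pattern other than a single para atom.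

An ethoxy, a hydroxy or an amine at the same place would help show whether the oxygen or the carbon of methoxy goes with the lower number. Nothing measured here explains why methoxy differs from the two halogens.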